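The source may hold more compounds than are shown below. What is called first, only, known or untested is meant among the compounds shown, and "the series" means these compounds.

Compound 1 `Nc1ccc(/C=C/C(=O)c2ccccc2)cc1` and compound 2 `COc1cccc(C(=O)/C=C/c2ccc(N)cc2)c1` share a core; in a functional assay on HeLa cells (Homo sapiens) for antiproliferative activity, with a stated time of 48 h (a lower number here means a stronger inhibitor, a higher number a weaker inhibitor), compound 1 gives 36000 nM and compound 2 gives 33000 nM, so the change methoxy in place of hydrogen on an aromatic carbon made a step of a 1.1-fold lower number from compound 1 to compound 2 (0.04 log units; within the scatter). Compound 3 `COc1cc(/C=C/C(=O)c2ccc(N)cc2)cc(OC)c1` gives 7900 nM in this assay, the lowest of the three numbers; how its core differs from that of compound 1 is not broken down here. Compound 4 `COc1cc(/C=C/C(=O)c2ccc(N)cc2)cc(OC)c1OC` differs from compound 3 by methoxy in place of hydrogen on an aromatic carbon, the same kind of change as from compound 1 to compound 2, though here the place is ortho to two methoxy groups and para to a large group rather than meta to a large group. Resting on compound 3 at 7900 nM and the small step of a 1.1-fold lower number from compound 1 to compound 2 (0.04 log units; within the scatter), the step from compound 3 to compound 4 is expected to be a 2.6-fold lower number from compound 3 to compound 4 (0.42 log units; beyond the scatter). Compound 4 is estimated at 3000 nM in this assay, between 600 nM and 15000 nM.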

Compound 4, half-maximal inhibitory concentration: 6900 nM
The estimate for compound 4 lay 2.3-fold (0.36 log units) below the measured number, within the range that was stated.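

In this assay, methoxy in place of hydrogen on an aromatic carbon made a step of a 1.1-fold lower number from compound 3 to compound 4 (0.06 log units; within the scatter), and the two cases of this change agree: the same change on two cores in this assay, a 1.1-fold lower number (0.04 log units; within the scatter) from compound 1 to compound 2 and a 1.1-fold lower number (0.06 log units; within the scatter) from compound 3 to compound 4, 1.0-fold (0.02 log units) apart, within the scatter of two such steps. In these two pairs, the change carried from one core to the other without a step beyond the scatter, even though in compound 4 the methoxy sits ortho to two methoxy groups and para to a large group. For the compounds shown here, this does not show that the change would behave alike on other cores or at other places, since it rests on only two pairs. The compounds shown leave open whether a group other than methoxy at this place, such as hydroxyl or fluorine, would give a step beyond the scatter.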